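Dropping the amino group from compound 3

The source may hold more compounds than are shown below. What is called first, only, known or untested is meant among the compounds shown, and "the series" means these compounds.

Of the compounds shown here, three have numbers so far in a functional assay on BT-474 cells (Homo sapiens) for antiproliferative activity, read by MTT assay, with a stated time of 72 h; on this read-out higher numbers stand for weaker inhibition and lower numbers for stronger inhibition. Compound 1 (`COc1cccc(CNc2ncnc3ccc(-c4cnn(C)c4)cc23)c1`) gives 30400 nM. Compound 2 (`CC(Nc1nc(N)nc2ccc(-c3cnn(C4CCNCC4)c3)cc12)c1c(Cl)ccc(F)c1Cl`) gives 5100 nM. Compound 3 (`CC(Oc1nc(N)nc2ccc(-c3cnn(C4CCNCC4)c3)cc12)c1c(Cl)ccc(F)c1Cl`) gives 3000 nM, which lies within the scatter of compound 2. The number for compound 1 is higher than that of compound 3, and that gap lies beyond the scatter.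

The next compound is compound 4 (`CC(Oc1ncnc2ccc(-c3cnn(C4CCNCC4)c3)cc12)c1c(Cl)ccc(F)c1Cl`), which has hydrogen in place of amino on an aromatic carbon, between two ring nitrogen atoms: hydrogen in place of amino on an aromatic carbon. Within the data shown here, no measured pair isolates this change, so its size cannot be read directly from the series. Compound 1, at 30400 nM, also has no amino group at that carbon, but its structure differs from the other two in further places, so it gives only a weak hint of direction. In this assay a modest step towards a higher number is expected, one that may well stay within the scatter. The estimated step is a 1.5-fold higher number from compound 3 to compound 4 (0.18 log units; within the scatter). For compound 4 the expected value is 4500 nM, with an estimated range from 1600 nM to 13000 nM.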

Compound 4, half-maximal inhibitory concentration: 4140 nM
Compound 4: middle estimate off by 1.1-fold (0.04 log units), on the high side, and the stated range covers the measured number.
By their numbers in this assay, from the lowest: compounds 3, 4 and 2 (each within the scatter of the next); then compound 1.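

In this assay, among these compounds, the change of hydrogen in place of amino on an aromatic carbon, between two ring nitrogen atoms, gives a 1.4-fold higher number from compound 3 to compound 4 (0.14 log units; within the scatter) and is the first step that isolates a single place. Within this pair, the amino group at this carbon is therefore not required for a number in this range, and the read-out does not separate the amino and hydrogen forms. Nothing measured here bears on why the two compounds read alike.

Still open, going by these compounds, is whether any other group at this carbon, such as methyl, methoxy or chlorine, would give a step beyond the scatter, or whether this position stays equally flat with those groups. Also open, on these data alone, is whether hydrogen in place of amino gives a step of similar size on compound 2, which carries the same amino group on the same carbon, since the present step comes from a single pair and cannot be extended to other members.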